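Cycloheptyl in place of an aryl group on the ring amine

A few compounds are considered here, and "the series" means these few. Any claim that something is new, unique, unknown or untested is made for them only; others in the source may bear on it.

Two compounds of this series carry a measured number. Compound 1 `Nc1scc(CN2CCN(c3ccc(Cl)cc3F)CC2)c1C(=O)c1ccc(Cl)cc1` is tested in a functional assay on CHO cells with adenosine receptor A1 (Homo sapiens) as the target, read by cAMP accumulation and immunoassay, with a stated time of 6 min, tested at 1 uM (a higher number here means a weaker effect of the compound at the concentration tested, a lower number a stronger effect), and gives -57%. Compound 2 `Nc1scc(CN2CCN(c3ccc(C(F)(F)F)cc3)CC2)c1C(=O)c1cccc(C(F)(F)F)c1` gives -27% in this assay. Compound 1 thus stands at the lowest of the two numbers, the stronger effect at the concentration tested; its nearest neighbour is compound 2, which sits beyond the scatter above it. Among the measured compounds shown here, no pair of measured compounds differs in a single place, so no single step has been quantified.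

Compound 3 `Nc1scc(CN2CCN(C3CCCCCC3)CC2)c1C(=O)c1ccc(Cl)cc1` is the next compound to go into this assay. Relative to compound 1 it differs as follows: cycloheptyl in place of 4-chloro-2-fluorophenyl on an amine nitrogen in a ring. The aromatic ring with its halogen atoms gives way to a saturated seven-membered carbon ring on the amine nitrogen in a ring.

For the measured compounds named here, no measured pair reports what such a change does to this read-out. The working expectation is a step from compound 1 to compound 3 of a number 17 percentage points higher from compound 1 to compound 3 (beyond the scatter), towards a weaker effect, with the possibility that it stays within the scatter. On that basis compound 3 is estimated to give -40% in this assay, with a range from -70% to -5%.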

Compound 3, a percentage reported as activity, at one concentration (the size of the read-out at that concentration, not a potency): 3.7%
The estimate for compound 3 lay 43.7 percentage points below the measured number, outside the stated range (above it).
By their numbers in this assay, from the lowest: compound 1; then compound 2; then compound 3.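

In this assay, among the compounds shown here, the substituent on the amine nitrogen in a ring proves to be a strong determinant of the read-out: cycloheptyl in place of 4-chloro-2-fluorophenyl gives a number 60.7 percentage points higher from compound 1 to compound 3 (beyond the scatter) with the rest of the structure unchanged, the first step that can be assigned to a single place. For the compounds shown here, of the three numbers, only the one for compound 3 at 3.7% is positive, so this change alone is enough to move the read-out to the other side of zero. Nothing at hand accounts for the size of this step.

The change removes the aromatic ring and both halogen atoms together, so the compounds shown cannot say which of these matters; an unsubstituted phenyl group on the same nitrogen would separate the two, while cyclohexyl or a straight heptyl chain would test the saturated ring itself. Going by these compounds, it also remains open whether the step holds with the 3-trifluoromethylphenyl ketone of compound 2 in place of the 4-chlorophenyl ketone shared by compound 1 and compound 3.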